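Swapping an Amide for an Oxadiazole on the Piperidine Ring

The compounds below may be only part of what the source reports. "The series", "measured", "known", "first", "only" and "open" are said of these compounds alone.

Three measured compounds share one core. In a functional assay on BXPC-3 cells (Homo sapiens) for inhibition, read by MTT assay, with a stated time of 7 days (on this read-out higher numbers stand for weaker inhibition and lower numbers for stronger inhibition), compound 1 `CCN(CC)S(=O)(=O)c1ccc(S(=O)(=O)N2CCC[C@@H](C(=O)N(C)C(C)C)C2)cc1` gives 7700 nM, the lowest of the two numbers in hand. Compound 2 `CCOC(=O)[C@H]1CCN(S(=O)(=O)c2ccc(S(=O)(=O)N(CC)CC)cc2)C1` gives 29300 nM in this assay, a higher number that lies beyond the scatter. For compound 3 `CCOC(=O)N1CCC[C@@H](S(=O)(=O)c2ccc(S(=O)(=O)N(CC)CC)cc2)C1` this assay reports only a limit, > 30000 nM, so no number is known; in fact (the limit of > 30000 nM in this assay, at which 1 of the 3 values shown sits).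

Compound 4 `CCN(CC)S(=O)(=O)c1ccc(S(=O)(=O)N2CCC[C@@H](c3nc(C)no3)C2)cc1` differs from compound 1 in one place: 3-methyl-1,2,4-oxadiazol-5-yl in place of isopropyl(methyl)carbamoyl on a saturated ring carbon. Within the data shown here, with no measured pair showing a comparable swap, a step of this kind is expected to stay within the scatter, in either direction. For compound 4 the estimate in this assay is 9000 nM, with a range from 3000 nM to 30000 nM, which is expected to mean a step of a 1.2-fold higher number from compound 1 to compound 4 (0.07 log units; within the scatter).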

Compound 4, half-maximal inhibitory concentration: 2900 nM
The estimate for compound 4 lay 3.1-fold (0.49 log units) above the measured number; the measured number lies below the stated range.
By their numbers in this assay, from the lowest: compound 4; then compound 1; then compound 2. At a limit, above all of these: compound 3.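

At this saturated ring carbon, the carbamoyl group is not required for activity in this assay: 3-methyl-1,2,4-oxadiazol-5-yl in its place brings a 2.7-fold lower number from compound 1 to compound 4 (0.42 log units; beyond the scatter). Among these compounds, the step is modest, yet it shows that a five-membered aromatic ring can stand at this position, which the earlier compounds could not show. Nothing measured here accounts for the step. Still open, from the compounds shown here alone, is how a carboxylic acid or an amine on this carbon would compare, and whether an ethyl or longer chain in place of the oxadiazole's methyl would change the number.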